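Ester in place of acid on a geranyloxy cinnamate

This account rests on a few compounds, and the source may have more. Where it says the series, first, only, none or still open, it means among the compounds named here.

Measured compounds in an assay on isolated protein for inhibition of geranylgeranyl pyrophosphate synthase (Homo sapiens), tested at 100 uM; a higher number here means more inhibition at the concentration tested (going by the name of the read-out), a lower number less inhibition:
compound 1 `CCOC(=O)/C=C/c1ccc(OC/C=C(\C)CCC=C(C)C)cc1`: 13.4%
compound 2 `CCOC(=O)/C=C/c1ccc(OC/C=C(\C)CCC=C(C)C)c(OC)c1`: 5.5%
compound 3 `CC(C)=CCC/C(C)=C/COc1ccc(/C=C/C(=O)O)cc1O`: 12.7%

Compound 3 sits close to compound 1 and compound 2; every gap among the three values falls within the scatter, so none can be ranked against another. Compound 4 `CCOC(=O)/C=C/c1ccc(OC/C=C(\C)CCC=C(C)C)c(O)c1` has not been tested. Its difference from compound 3 is ethyl in place of hydrogen on an oxygen next to a carbonyl group. Among the compounds with values here, no measured pair shows this change on its own. Within the data shown here, the only single step on record, a number 7.9 percentage points lower from compound 1 to compound 2 (within the scatter), concerns a different change and therefore carries no weight here. With nothing pointing in either direction, no step beyond the scatter in this assay is expected, and the step of a number 0.7 percentage points lower from compound 3 to compound 4 (within the scatter) is the estimate. Compound 4 is expected to give 12%, between 2% and 22%.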

Compound 4, a percentage reported as inhibition, at one concentration (the size of the read-out at that concentration, not a potency): -7.4%
The estimate for compound 4 lay 19.4 percentage points above the measured number; measured number outside the range, below it.
By their numbers in this assay, from the lowest: compound 4; then compounds 2, 3 and 1 (each within the scatter of the next).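

Ethyl in place of hydrogen on an oxygen next to a carbonyl group, the change from carboxy to ethoxycarbonyl, is now seen on its own as a number 20.1 percentage points lower from compound 3 to compound 4 (beyond the scatter) in this assay and matters when the hydroxy group is present. Among the ethyl esters, the hydroxy group also counts, with a number 20.8 percentage points lower from compound 1 to compound 4 (beyond the scatter) and a number 12.9 percentage points lower from compound 2 to compound 4 (beyond the scatter) for hydrogen in place of methyl on that oxygen. Nothing measured here explains these steps. From the compounds shown here alone, an amide at the same place, or a longer chain than ethyl on that oxygen, remains open.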